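Removing the Amino Group from Compound 3

A few compounds are considered here, and "the series" means these few. Any claim that something is new, unique, unknown or untested is made for them only; others in the source may bear on it.

Three chalcones have been tested in a functional assay on A549 cells (Homo sapiens) for cytotoxicity, read by sulforhodamine B assay, with a stated time of 48 h; a lower number here means a stronger inhibitor, a higher number a weaker inhibitor. Compound 1 `COc1ccc(/C=C/C(=O)c2cccc(-c3cccc(F)c3)c2)cc1` gives 2440 nM. Compound 2 `Nc1ccc(C(=O)/C=C/c2ccc(O)c(F)c2)cc1-c1ccc(F)cc1` gives 24500 nM. Compound 3 `COc1ccc(/C=C/C(=O)c2ccc(N)c(-c3ccc(F)cc3)c2)cc1` gives 4310 nM, the second highest of the three numbers; its gap to compound 1 lies within the scatter, while its gap to compound 2 lies beyond it, as the step of a 5.7-fold lower number from compound 2 to compound 3 (0.75 log units; beyond the scatter) shows.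

Compound 4 `COc1ccc(/C=C/C(=O)c2cccc(-c3ccc(F)cc3)c2)cc1` is the unmeasured target. Compared with compound 3, the change is hydrogen in place of amino on an aromatic carbon. Among the compounds with values here, no measured step covers this change: the single step on record concerns the other aryl group. Within the data shown here, the only hint is that compound 1, which also lacks the amino group but carries a 3-fluorophenyl group, sits within the scatter of compound 3. Compound 4 is therefore expected to show a step of a 1.4-fold lower number from compound 3 to compound 4 (0.16 log units; within the scatter), not beyond the scatter. The estimate for compound 4 in this assay is 3000 nM, with a range from 1200 nM to 8000 nM.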

Compound 4, half-maximal inhibitory concentration: 11200 nM
Estimate against measurement, compound 4: 3.7-fold (0.57 log units) below, outside the stated range (above it).
By their numbers in this assay, from the lowest: compounds 1 and 3 (each within the scatter of the next); then compound 4; then compound 2.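

In this assay, replacing the amino group with hydrogen gives a 2.6-fold higher number from compound 3 to compound 4 (0.41 log units; beyond the scatter), so on this pair the aromatic carbon ortho to a 4-fluorophenyl group is a position where the amino group goes with a lower number. The place of the fluorine on the aryl group also counts among compounds without the amino group, with a 4.6-fold higher number from compound 1 to compound 4 (0.66 log units; beyond the scatter) when 4-fluorophenyl stands in place of 3-fluorophenyl, so compound 1 does not show how the amino group's removal behaves with 4-fluorophenyl. Nothing measured on these compounds offers a reason for either step.

From the compounds shown here alone, it remains open whether a dimethylamino group or an acetamide at this aromatic carbon would keep the number of compound 3. Also open, going by these compounds, is whether adding an amino group to compound 1 would shift its number in the same direction.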